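The compounds below may be only part of what the source reports. "The series", "measured", "known", "first", "only" and "open" are said of these compounds alone.

Measured so far in an ADME assay on MRC5 cells (Homo sapiens) for inhibition, with a stated time of 72 h; a higher number here means that more compound is needed for the effect, a lower number that less compound is needed:

Compound 1 `CO[C@H]1CC[C@H](NC(=O)c2n[nH]cc2NC(=O)c2ncoc2-c2ccccc2)CC1`: 28000 nM
Compound 2 `COc1cccc(OC)c1C(=O)Nc1c[nH]nc1C(=O)NC1CC1`: > 50000 nM

In this assay compound 2 gives > 50000 nM, which is a limit of the assay and not a number. Its true position is therefore unknown, and any step away from it is hard to size.

Compound 3 `COc1cccc(OC)c1C(=O)Nc1c[nH]nc1C(=O)NC1CC2CCC1C2` keeps the core of compound 2 and changes only the group on the amide-type nitrogen: a group of 7 heavy atoms (7 carbon; 2 five-membered non-aromatic rings of carbon only) in place of a group of 3 heavy atoms (3 carbon; one three-membered non-aromatic ring of carbon only), on an amide-type nitrogen. Within the data shown here, no pair of measured compounds differs in one place, so there is no direct precedent for this change. Compound 1 gives 28000 nM, which shows that a measurable number can occur among these compounds.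

A small step is expected, if any, towards less compound being needed: an at least 1.1-fold lower number from compound 2 to compound 3 (0.04 log units; that floor lies within the scatter). The assay may again report only a limit. For compound 3 the estimated value is 45000 nM, with an expected range from 20000 nM to 50000 nM.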

Compound 3, half-maximal effective concentration: > 50000 nM
Compound 3: a limit, no number; the forecaster's own chance of this, stated with the estimate: 60%; middle value at least 1.1-fold (0.04 log units) from the limit.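

Compound 3 gives > 50000 nM, a limit and not a number. No step from compound 2 to compound 3 can be read, since compound 2 also gives only a limit: the limit of > 50000 nM in this assay, at which 2 of the 3 values shown sit.

Going by these compounds, whether the group of 7 heavy atoms in place of cyclopropyl changes the amount of compound needed stays open.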